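The source may hold more compounds than are shown below. What is called first, only, known or untested is meant among the compounds shown, and "the series" means these compounds.

Measured in a functional assay on HUVEC cells (Homo sapiens) for inhibition, with a stated time of 4 days; on this read-out lower numbers stand for stronger inhibition and higher numbers for weaker inhibition:
Compound 1 `COc1ccc(C(N)=O)cc1/C=C/c1ccccc1`: 2400 nM
Compound 2 `COc1ccc(C(N)=O)cc1/C=C/c1ccc(C)cc1`: 1600 nM
Compound 3 `COc1ccc(C(N)=O)cc1/C=C/c1ccc([N+](=O)[O-])cc1`: 4700 nM

Compound 1, at 2400 nM, lies within the usual scatter of repeated measurements of both other compounds. Only those two are clearly separated from each other, with a modest gap: a 2.9-fold higher number from compound 2 to compound 3 (0.47 log units; beyond the scatter).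

Compound 4 `COc1ccc(C(N)=O)cc1/C=C/c1cccc(Cl)c1` has not yet been measured. It differs from compound 1 by a single change, chloro in place of hydrogen on an aromatic carbon, meta to a large group. For the measured compounds named here, no measured compound carries chloro, so the data offer only indirect guidance. The closest evidence comes from two other replacements of hydrogen on an aromatic carbon, methyl in compound 2 and nitro in compound 3. These give a 1.5-fold lower number from compound 1 to compound 2 (0.18 log units; within the scatter) and a 2.0-fold higher number from compound 1 to compound 3 (0.29 log units; within the scatter). Neither step leaves the scatter, so no step beyond the scatter is expected in this assay, and no direction can be predicted with confidence. The expected step is a 1.1-fold lower number from compound 1 to compound 4 (0.04 log units; within the scatter).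

For compound 4 the estimated value is 2200 nM, with an expected range from 1100 nM to 4500 nM.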

Compound 4, half-maximal inhibitory concentration: 24000 nM
Beside the measured number, compound 4's estimate is 11-fold (1.04 log units) below it, outside the stated range (above it).
By their numbers in this assay, from the lowest: compounds 2, 1 and 3 (each within the scatter of the next, the first and the last beyond it); then compound 4.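

In this assay, chloro in place of hydrogen on an aromatic carbon, meta to a large group, gives a 10-fold higher number from compound 1 to compound 4 (1.00 log units; beyond the scatter). For the compounds shown here, this is the first replacement of hydrogen on this ring to leave the scatter when measured from compound 1, as the earlier steps stayed within it: a 1.5-fold lower number from compound 1 to compound 2 (0.18 log units; within the scatter) and a 2.0-fold higher number from compound 1 to compound 3 (0.29 log units; within the scatter). It shows that adding a single chlorine atom to this ring can clearly weaken inhibition, so the small steps seen earlier do not hold for every replacement of hydrogen, although no measurement shown here accounts for the size of this step.

The compounds shown hold no other group at this place and no chloro elsewhere on the ring, so it remains open whether the higher number goes with chloro itself or with the place it occupies. Fluoro, an amine or a carboxylic acid at this same place would show whether any replacement of hydrogen here raises the number or only some do.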